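Replacing 4-(trifluoromethyl)phenyl with naphthalen-2-yl in compound 3

This account rests on a few compounds, and the source may have more. Where it says the series, first, only, none or still open, it means among the compounds named here.

Measured in a functional assay on SW-620 cells (Homo sapiens) for cytotoxicity, read by MTT assay, with stated times of 4 h and 72 h, tested at 2 uM; a higher number here means a weaker inhibitor, a lower number a stronger inhibitor:

- Compound 1 `Cc1cc(Nc2ccc(C(=O)/C=C/c3ccc4ccccc4c3)cc2)n2nc(SCc3cccc4ccccc34)nc2n1`: 68 nM
- Compound 2 `Cc1cc(Nc2ccc(C(=O)/C=C/c3ccccc3)cc2)n2nc(SCc3nc4ccccc4[nH]3)nc2n1`: 130 nM
- Compound 3 `Cc1cc(Nc2ccc(C(=O)/C=C/c3ccc(C(F)(F)F)cc3)cc2)n2nc(SCc3nc4ccccc4[nH]3)nc2n1`: 1850 nM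

Of these three, compound 3 has the highest number, 1850 nM, which makes it the weakest inhibitor of the set. Compound 4 `Cc1cc(Nc2ccc(C(=O)/C=C/c3ccc4ccccc4c3)cc2)n2nc(SCc3nc4ccccc4[nH]3)nc2n1` has not yet been measured. It differs from compound 3 in one place, on a double-bonded chain carbon bound to a double-bonded chain carbon: naphthalen-2-yl in place of 4-(trifluoromethyl)phenyl on a double-bonded chain carbon bound to a double-bonded chain carbon.

Within the data shown here, only one measured step bears directly on this change. Putting trifluoromethyl in place of hydrogen on an aromatic carbon gave a 14-fold higher number from compound 2 to compound 3 (1.15 log units; beyond the scatter), a large step beyond the scatter. Compound 4 also lacks the trifluoromethyl group, but it carries a second aromatic ring instead of returning to the plain phenyl of compound 2. Compound 1 carries the same naphthalen-2-yl group and gives 68 nM, although it differs from compound 4 elsewhere in the molecule. Among the measured compounds shown here, no measured pair isolates the effect of naphthalen-2-yl, so the uncertainty is wide.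

A clearly lower number is therefore expected, and the estimated change is a 6.6-fold lower number from compound 3 to compound 4 (0.82 log units; beyond the scatter). The expected value for compound 4 is 280 nM, with an estimated range from 80 nM to 1000 nM.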

Compound 4, half-maximal inhibitory concentration: 5 nM
The estimate for compound 4 lay 56-fold (1.75 log units) above the measured number, outside the stated range (below it).
By their numbers in this assay, from the lowest: compound 4; then compounds 1 and 2 (each within the scatter of the next); then compound 3.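

In this assay, the two-ring naphthalen-2-yl group on a double-bonded chain carbon bound to a double-bonded chain carbon does far more than undo the loss seen with trifluoromethyl: replacing 4-(trifluoromethyl)phenyl gives a 370-fold lower number from compound 3 to compound 4 (2.57 log units; beyond the scatter), and replacing plain phenyl still gives a 26-fold lower number from compound 2 to compound 4 (1.41 log units; beyond the scatter), so losing trifluoromethyl cannot be the whole gain. The other end of the molecule also matters, since with naphthalen-2-yl held constant, 1H-benzimidazol-2-yl in place of naphthalen-1-yl on a saturated chain carbon bound to a sulfur gives a 14-fold lower number from compound 1 to compound 4 (1.13 log units; beyond the scatter), making compound 4 the strongest inhibitor of the four. Nothing available here explains either gain.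

The compounds shown leave open whether this gain belongs to naphthalen-2-yl specifically or would also appear with naphthalen-1-yl or a quinolinyl ring on the same chain carbon. They also leave open whether a smaller group such as fluoro or methoxy on the phenyl ring would carry the same penalty as trifluoromethyl.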